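Taking the Trifluorophenyl off the Amine Nitrogen

The compounds below may be only part of what the source reports. "The series", "measured", "known", "first", "only" and "open" are said of these compounds alone.

Compound 2 `Cc1ccc(S(=O)(=O)/N=C(/CCNC2=CC(=O)c3ccccc3C2=O)Nc2cc(F)c(F)c(F)c2)cc1` gives 6610 nM in a functional assay on MCF7 cells (Homo sapiens) for cytotoxicity, read by MTT assay, with a stated time of 48 h (on this read-out higher numbers stand for weaker inhibition and lower numbers for stronger inhibition), the lowest of the two numbers, while compound 1 `Cc1ccc(S(=O)(=O)/N=C(/CCNC2=CC(=O)c3ccccc3C2=O)Nc2ccc(F)c(F)c2)cc1` at 9420 nM lies within the scatter of it. Compound 3 `Cc1ccc(S(=O)(=O)/N=C(\N)CCNC2=CC(=O)c3ccccc3C2=O)cc1` differs from compound 2 by hydrogen in place of 3,4,5-trifluorophenyl on an amine nitrogen. Within the data shown here, the only measured step, a 1.4-fold lower number from compound 1 to compound 2 (0.15 log units; within the scatter), alters this same 3,4,5-trifluorophenyl group, yet it merely adds one fluorine rather than removing the whole group, so it bears only loosely on the change. Among the measured compounds shown here, with no step covering such a loss, the estimate is uncertain but leans toward weaker inhibition. Compound 3 is expected near 20000 nM, between 5000 nM and 70000 nM. The expected step is a 3.0-fold higher number from compound 2 to compound 3 (0.48 log units; beyond the scatter).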

Compound 3, half-maximal inhibitory concentration: 18600 nM
Estimate against measurement, compound 3: 1.1-fold (0.03 log units) above; low and high end bracket the measured number.
By their numbers in this assay, from the lowest: compounds 2, 1 and 3 (each within the scatter of the next, the first and the last beyond it).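

In this assay, replacing 3,4,5-trifluorophenyl with hydrogen on the amine nitrogen gives a 2.8-fold higher number from compound 2 to compound 3 (0.45 log units; beyond the scatter), so at this position the loss of the whole group registers, though modestly. The same replacement of 3,4-difluorophenyl gives a 2.0-fold higher number from compound 1 to compound 3 (0.30 log units; within the scatter), so the size of the effect depends on which compound is the starting point. No measurement bearing on the cause of either step is available. Open, from the compounds shown here alone, is whether a methyl group or an unsubstituted phenyl on this nitrogen would read closer to compound 2 or to compound 3.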